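Aryl swap on the ring nitrogen of the shared core

The source may report more compounds than this note shows. Statements on the series, on what has been measured and on what is new or still open speak of the compounds shown alone.

Compound 1 `COc1ccc(-n2ncnc2-c2cc(OC)c(OC)c(OC)c2)cc1` — > 10000 nM
Compound 2 `COc1cc(-c2ncnn2-c2ccc([N+](=O)[O-])cc2)cc(OC)c1OC` — > 10000 nM
Compound 3 `COc1cccc(-c2ncnn2-c2cc(OC)c(OC)c(OC)c2)c1` — > 10000 nM

In a functional assay on HeLa cells (Homo sapiens) for antiproliferative activity, read by MTT assay, with a stated time of 72 h (a lower number here means a stronger inhibitor, a higher number a weaker inhibitor), compound 1 gives > 10000 nM, which is a limit of the assay and not a number. Compound 2 likewise stops at a limit, > 10000 nM. Compound 3 also stops at a limit, > 10000 nM. Compound 1 therefore cannot be placed on a scale against its neighbours, since every value shown is a limit (the limit of > 10000 nM in this assay, at which 3 of the 3 values shown sit). Within the data shown here, the one single-point step, a step that the two limits leave unreadable from compound 1 to compound 2, is unreadable. The change to compound 4 `COc1cc(-c2ncnn2-c2cccc(F)c2)cc(OC)c1OC` is 3-fluorophenyl in place of 4-methoxyphenyl on an aromatic nitrogen. No readable measured step bears on this change, so neither size nor direction can be drawn from the series. Compound 4 is expected to stay at the limit of this assay, with an estimate of 15000 nM, between 5000 nM and 50000 nM. The expected step is a step that the limit leaves unreadable from compound 1 to compound 4.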

Compound 4, half-maximal inhibitory concentration: > 10000 nM
Compound 4 gave a limit, no number; the forecaster's own chance of this, stated with the estimate: 80%; the middle value does not contradict the limit.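

No new step can be read: compound 1 and compound 4 both give only a limit, not a number: the limit of > 10000 nM in this assay, at which 4 of the 4 values shown sit.

The compounds shown leave open whether any aryl group on the aromatic nitrogen of the shared core gives a readable number.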